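This account rests on a few compounds, and the source may have more. Where it says the series, first, only, none or still open, it means among the compounds named here.

Series notes. One shared core runs through the three measured compounds: compound 1 `O=C(N/N=C/c1ccccc1)c1cccnc1Nc1cccc(C(F)(F)F)c1`, compound 2 `COc1cccc(/C=N/NC(=O)c2cccnc2Nc2cccc(C(F)(F)F)c2)c1` and compound 3 `COc1ccc(/C=N/NC(=O)c2cccnc2Nc2cccc(C(F)(F)F)c2)cc1`. In a functional assay on the whole organism (strain Wistar) for inhibition, with Rattus norvegicus as the target, read by paw edema, with a stated time of 3 h, at a dose of 10 mg/kg by the intraperitoneal route (a higher number here means more inhibition at the dose given (going by the name of the read-out), a lower number less inhibition), compound 1 gives 21.2%, compound 2 gives 30.3%, and compound 3 gives 26.5%. On these three numbers compound 3 stands second highest, yet its gaps to both other compounds fall within the scatter, so no order among the three is secure. The two steps that put a methoxy onto an aromatic carbon read a number 9.1 percentage points higher from compound 1 to compound 2 (within the scatter) and a number 5.3 percentage points higher from compound 1 to compound 3 (within the scatter), each within the scatter; the shift of the methoxy from one ring position to the other reads a number 3.8 percentage points lower from compound 2 to compound 3 (within the scatter), also within the scatter.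

Compound 4 `COc1ccc(/C=N/NC(=O)c2cccnc2Nc2cccc(C(F)(F)F)c2)c(OC)c1` has not yet been measured in this assay. It differs from compound 3 in one place: methoxy in place of hydrogen on an aromatic carbon. For the measured compounds named here, the two measured methoxy additions are the steps that bear on this change; each stayed within the scatter, with a slight lean toward more inhibition. The expected step is accordingly a number 3 percentage points higher from compound 3 to compound 4 (within the scatter), small and, if anything, upward, with no change beyond the scatter anticipated. Compound 4 is estimated at 29.5% in this assay, with a range from 18% to 41%.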

Compound 4, a percentage reported as inhibition, in the whole organism at one dose (the size of the read-out at that dose, not a potency): 24.1%
Estimate against measurement, compound 4: 5.4 percentage points above, within the range that was stated.
By their numbers in this assay, from the lowest: compounds 1, 4, 3 and 2 (each within the scatter of the next).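

In this assay, the methoxy added ortho to a large group and meta to a methoxy group reads a number 2.4 percentage points lower from compound 3 to compound 4 (within the scatter), so the slight upward lean of the two earlier methoxy additions does not carry over to this position. Exchanging the whole aryl group leads to the same reading, with a number 6.2 percentage points lower from compound 2 to compound 4 (within the scatter) and a number 2.9 percentage points higher from compound 1 to compound 4 (within the scatter), so 2,4-dimethoxyphenyl cannot be told apart from phenyl or 3-methoxyphenyl on these numbers. Comparing the methoxy addition on two cores shows no dependence on the core that can be separated from the scatter: the same change on two cores in this assay, a number 9.1 percentage points higher (within the scatter) from compound 1 to compound 2 and a number 2.4 percentage points lower (within the scatter) from compound 3 to compound 4, 11.5 percentage points apart, within the scatter of two such steps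

As far as these compounds go, every step among the four compounds stays within the scatter, so it remains open whether this position influences the inhibition of paw edema at all. What a hydroxyl, an amine or a carboxylic acid at this position would read in this assay also remains open, as each is a group not among the compounds shown and could show whether any change here moves the number beyond the scatter.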